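The source may hold more compounds than are shown below. What is called first, only, known or untested is meant among the compounds shown, and "the series" means these compounds.

Compound 2 `O=C(NOCc1ccccc1Cl)c1cn(-c2ccccc2)nc1-c1ccccc1` gives 10300 nM in a functional assay on A549 cells (Homo sapiens) for antiproliferative activity, read by MTT assay, with a stated time of 48 h, in the presence of a further agent that is not named here (on this read-out higher numbers stand for weaker inhibition of growth and lower numbers for stronger inhibition of growth), and compound 1 `O=C(NOCc1ccccc1F)c1cn(-c2ccccc2)nc1-c1ccccc1` gives 5940 nM; the step of a 1.7-fold higher number from compound 1 to compound 2 (0.24 log units; within the scatter) leaves the two within the scatter of each other. Compound 3 `O=C(NOCc1ccccc1Cl)c1cn(-c2ccccc2)nc1-c1ccc(Cl)cc1` differs from compound 2 by chloro in place of hydrogen on an aromatic carbon, placed on an aromatic carbon of a six-membered aromatic ring of carbon only. Among the measured compounds shown here, no measured step trades hydrogen for chloro; the single known step, chloro in place of fluoro, stayed within the scatter. Compound 3 is therefore expected to show no shift beyond the scatter, a 1.0-fold lower number from compound 2 to compound 3 (0.01 log units; within the scatter), with an estimate of 10000 nM between 4000 nM and 30000 nM.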

Compound 3, concentration for 50% growth inhibition: 15500 nM
The estimate for compound 3 lay 1.6-fold (0.19 log units) below the measured number, and the stated range covers the measured number.
By their numbers in this assay, from the lowest: compounds 1, 2 and 3 (each within the scatter of the next, the first and the last beyond it).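

In this assay, the change from phenyl to 4-chlorophenyl gives a 1.5-fold higher number from compound 2 to compound 3 (0.18 log units; within the scatter). This is the first step shown that puts chloro in place of hydrogen, and it shows that this aromatic carbon, para to a large group, takes a chlorine without a shift beyond the scatter. No measurement offered here explains this result. Going by these compounds, it remains open whether an amine, a carboxylic acid or a methoxy group on this carbon would move the number beyond the scatter.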